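The compounds below may be only part of what the source reports. "The series", "measured", "known", "first", "only" and "open" are said of these compounds alone.

Working notes on the series. Compound 2 `CCN1C(=O)C(=O)c2cc(-c3ccc(OC)cc3)ccc21` gives 4470 nM in a functional assay on HepG2 cells (Homo sapiens) for antiproliferative activity, read by MTT assay, with a stated time of 48 h; a higher number here means a weaker inhibitor, a lower number a stronger inhibitor; compound 1 `COc1ccc(-c2ccc3c(c2)C(=O)C(=O)N3C)cc1` gives 6670 nM. Compound 2 therefore has the lower of the two numbers shown, but the step of a 1.5-fold lower number from compound 1 to compound 2 (0.17 log units; within the scatter) is within the scatter, so nothing separates the two on this assay.

Compound 3 `COc1ccc(-c2ccc3c(c2)C(=O)C(=O)N3c2ccc(OC)cc2)cc1` differs from compound 2 in one place: 4-methoxyphenyl in place of ethyl on an amide-type nitrogen in a ring. For the measured compounds named here, the only measured step at this nitrogen is a 1.5-fold lower number from compound 1 to compound 2 (0.17 log units; within the scatter), a small change in substituent that moved the number by an amount within the scatter. Going by the values given here, the present change is larger in what it adds, and no measured pair covers an aryl group at this position, so the data give no direction for it. The step expected from compound 2 to compound 3 is a 1.1-fold lower number from compound 2 to compound 3 (0.05 log units; within the scatter), with wide uncertainty. Compound 3 is estimated at 4000 nM in this assay, between 1200 nM and 13000 nM.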

Compound 3, half-maximal inhibitory concentration: > 10000 nM
Compound 3 ended at the assay's limit; the forecaster's own chance of this, stated with the estimate: 5%; at least 2.5-fold (0.39 log units) between middle value and limit.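

In this assay compound 3 gives > 10000 nM, which is a limit of the assay and not a number. For the compounds shown here, the step of an at least 2.2-fold higher number from compound 2 to compound 3 (0.34 log units; beyond the scatter) is the first at this amide-type nitrogen that lies beyond the scatter, so the position does respond to its substituent, and 4-methoxyphenyl falls on the weaker side of ethyl. The step of an at least 1.4-fold higher number from compound 1 to compound 3 (0.17 log units; that floor lies within the scatter) has a floor within the scatter, so the comparison with methyl does not establish this on its own.

As far as these compounds go, only a floor is known for both steps, so the full size of the change stays open: the limit of > 10000 nM in this assay, at which 1 of the 3 values shown sits. Also open is whether the higher number goes with the aromatic ring or with its methoxy group, and how a plain phenyl, a benzyl group or a longer chain carrying an amine would read at this nitrogen.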